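The compounds below may be only part of what the source reports. "The series", "measured", "known", "first", "only" and "open" are said of these compounds alone.

Working notes on the series in an ADME assay on HEp-2 cells (Homo sapiens) for cytotoxicity; a lower number here means that less compound is tolerated, a higher number that more compound is tolerated. Compound 1 `C=C(C)n1c(=O)n(Cc2nc3ccccc3n2CCC(C)C)c2ccccc21` gives 24600 nM. Compound 2 `CC(C)CCn1c(Cn2c(=O)n(CC(=O)OC(C)(C)C)c3ccccc32)nc2cc(C(=N)N)ccc21` gives 7900 nM. Compound 3 `C=C(C)n1c(=O)n(Cc2nc3cc(/C(N)=N\O)ccc3n2CCC(C)C)c2ccccc21` gives 3470 nM, the lowest of the three numbers; compound 2 stands nearest and compound 1 furthest from it. Within the data shown here, the one counted step, a 7.1-fold lower number from compound 1 to compound 3 (0.85 log units; beyond the scatter), concerns the group on the aromatic carbon and says nothing about the change now in view. Compound 4 `CC(C)CCn1c(Cn2c(=O)n(CC(=O)OC(C)(C)C)c3ccccc32)nc2cc(/C(N)=N\O)ccc21` differs from compound 3 by (tert-butoxycarbonyl)methyl in place of 1-methylethenyl on an aromatic nitrogen. Among the measured compounds shown here, no measured pair isolates this exchange. Compound 2 already bears the entering (tert-butoxycarbonyl)methyl group and differs from compound 4 elsewhere; its number and that of compound 3 lie close together, a little above the scatter. For the measured compounds named here, on this basis no step well beyond the scatter is expected for compound 4, with a slight lean upward toward the number of compound 2. The expected step of a 1.4-fold higher number from compound 3 to compound 4 (0.16 log units; within the scatter) is small. Compound 4 is therefore estimated at 5000 nM, within 1500 nM to 15000 nM.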

Compound 4, half-maximal cytotoxic concentration: 19800 nM
Compound 4: middle estimate off by 4.0-fold (0.60 log units), on the low side; measured number above the stated range.
By their numbers in this assay, from the lowest: compound 3; then compound 2; then compounds 4 and 1 (each within the scatter of the next).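

In this assay, the exchange of 1-methylethenyl for (tert-butoxycarbonyl)methyl on the aromatic nitrogen can now be read as a single change, and the position proves responsive to it: the step is a 5.7-fold higher number from compound 3 to compound 4 (0.76 log units; beyond the scatter). With (tert-butoxycarbonyl)methyl held constant, the group on the aromatic carbon also matters, since the exchange of the group at that place gives a 2.5-fold higher number from compound 2 to compound 4 (0.40 log units; beyond the scatter). Nothing at hand bears on the origin of either step.

As far as these compounds go, how a free carboxylic acid or a plain methyl on the same aromatic nitrogen would stand remains open. Among these compounds, also open is whether the exchange gives a step of similar size with hydrogen on the aromatic carbon, as it is read here with only one group at that place.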